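The compounds below may be only part of what the source reports. "The series", "measured", "known", "first", "only" and "open" are said of these compounds alone.

Compound 1 `Nc1ccc(-c2nnn(Cc3c(F)cc(C(=O)NO)cc3F)n2)cc1` gives 3 nM in an assay on Sf9 cells for inhibition of protein deacetylase HDAC6 (Homo sapiens), read by fluorescence; a higher number here means a weaker inhibitor, a lower number a stronger inhibitor. Compound 2 `NCc1ccc(-c2nnn(Cc3c(F)cc(C(=O)NO)cc3F)n2)cc1` gives 4 nM. Compound 3 `Nc1ccc(-c2nnn(Cc3ccc(C(=O)NO)cc3)n2)cc1` gives 1 nM.

Compound 2 differs from compound 1 by a single change, (aminomethyl in place of amino on an aromatic carbon). That change made a step of a 1.3-fold higher number from compound 1 to compound 2 (0.12 log units; within the scatter). Compound 4 `NCc1ccc(-c2nnn(Cc3ccc(C(=O)NO)cc3)n2)cc1` has not yet been measured; it differs from compound 3 by the same change, (aminomethyl in place of amino on an aromatic carbon), and the place of the change is the same in both pairs. The difference between the core of compound 1 and the core of compound 3 is not broken down here; their values show compound 3 with the lower number. Because the step of a 1.3-fold higher number from compound 1 to compound 2 (0.12 log units; within the scatter) lay within the scatter, the expected step from compound 3 to compound 4 in this assay is a 1.3-fold higher number from compound 3 to compound 4 (0.11 log units; within the scatter), also within the scatter. Compound 4 is therefore expected to give 1.3 nM, estimated between 0.6 nM and 3 nM.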

Compound 4, half-maximal inhibitory concentration: 2 nM
The estimate for compound 4 lay 1.5-fold (0.19 log units) below the measured number; the range from low to high includes it.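

Carried to the other core in this assay, aminomethyl in place of amino gave a 2.0-fold higher number from compound 3 to compound 4 (0.30 log units; within the scatter), a step too small to tell from repeat-measurement noise. The two steps agree: the same change on two cores in this assay, a 1.3-fold higher number (0.12 log units; within the scatter) from compound 1 to compound 2 and a 2.0-fold higher number (0.30 log units; within the scatter) from compound 3 to compound 4, 1.5-fold (0.18 log units) apart, within the scatter of two such steps. This shows that the change behaved alike on these two cores, with neither step large enough to separate aminomethyl from amino, but two pairs do not show that it would carry to other cores in the series.

The compounds shown leave open what a longer chain, such as aminoethyl, would do in this place. They also leave open the effect of a group of another kind there, such as a carboxylic acid.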